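Swapping Methyl for Phenyl on a Ring Nitrogen

This account rests on a few compounds, and the source may have more. Where it says the series, first, only, none or still open, it means among the compounds named here.

Compound 1 `O=C(CN1CCCCC1)NCCNc1cc(/C=C/c2ccccc2)nc2ccccc12`: 4700 nM
Compound 2 `CN1CCN(CC(=O)NCCNc2cc(/C=C/c3ccccc3)nc3ccccc23)CC1`: 34000 nM

Going by the values given here, in an ADME assay on J774 cells (Mus musculus) for cytotoxicity, read by MTT assay, with a stated time of 48 h (a lower number here means a stronger inhibitor, a higher number a weaker inhibitor), compound 2 gives the higher of the two numbers; the only step measured, a 7.2-fold higher number from compound 1 to compound 2 (0.86 log units; beyond the scatter), separates it from compound 1. Compound 3 `O=C(CN1CCN(c2ccccc2)CC1)NCCNc1cc(/C=C/c2ccccc2)nc2ccccc12` differs from compound 2 in one place: phenyl in place of methyl on an amine nitrogen in a ring. Among the compounds with values here, no measured step bears on this change, since the one step measured exchanges a whole ring rather than a group on its nitrogen, so its size is no guide here. With nothing firmer to lean on, the number for compound 3 is expected to stay near that of compound 2, a step of a 1.9-fold lower number from compound 2 to compound 3 (0.28 log units; within the scatter). The estimate for compound 3 is 18000 nM, between 5000 nM and 60000 nM.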

Compound 3, half-maximal inhibitory concentration: 4500 nM
For compound 3 the middle estimate is 4.0-fold (0.60 log units) above the measured one; measured number below the stated range.
By their numbers in this assay, from the lowest: compounds 3 and 1 (each within the scatter of the next); then compound 2.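

In this assay the group on the ring nitrogen clearly counts: phenyl in place of methyl gives a 7.6-fold lower number from compound 2 to compound 3 (0.88 log units; beyond the scatter) and so shows that the piperazine ring alone does not fix the number. Exchanging piperidin-1-yl for 4-phenylpiperazin-1-yl gives a 1.0-fold lower number from compound 1 to compound 3 (0.02 log units; within the scatter) and leaves these two compounds indistinguishable in this test. No supporting measurement accounts for either step. As far as these compounds go, whether ethyl, benzyl or acetyl on this nitrogen would read like methyl or like phenyl remains open. So does the effect of a substituted phenyl ring there.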